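Working notes: aryl swap on the double-bonded nitrogen

The compounds below may be only part of what the source reports. "The series", "measured", "known", "first", "only" and "open" are said of these compounds alone.

Compound 1 `COc1ccc(/C=C2/CN(C)/C(=N/c3ccc(OC)cc3)S2)cc1` gives 65900 nM
Compound 2 `COc1ccc(/C=C2\S/C(=N\c3ccc(C)c(Cl)c3)N(C)C2=O)cc1` gives 23000 nM

In an ADME assay on TERT-RPE1 cells (Homo sapiens) for cytotoxicity, read by MTT assay, with a stated time of 72 h (on this read-out lower numbers stand for stronger inhibition and higher numbers for weaker inhibition), compound 2 stands lowest of the two at 23000 nM, with compound 1 higher by more than the scatter. Compound 3 `COc1ccc(/C=C2\S/C(=N\c3ccc(OC)cc3)N(C)C2=O)cc1` follows from compound 2 by 4-methoxyphenyl in place of 3-chloro-4-methylphenyl on a double-bonded nitrogen. Going by the values given here, no one-place step between measured compounds is available to size this change. A small rise in this assay, within the scatter, is expected since compound 1 at 65900 nM also carries 4-methoxyphenyl. The expected step is a 1.4-fold higher number from compound 2 to compound 3 (0.14 log units; within the scatter). Compound 3 is estimated at 32000 nM, with an expected range of 12000 nM to 80000 nM.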

Compound 3, half-maximal inhibitory concentration: > 100000 nM
Compound 3 ended at the assay's limit; the forecaster's own chance of this, stated with the estimate: 15%; middle value at least 3.1-fold (0.49 log units) away from the limit.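

In this assay, 4-methoxyphenyl in place of 3-chloro-4-methylphenyl on the double-bonded nitrogen gives an at least 4.3-fold higher number from compound 2 to compound 3 (0.63 log units; beyond the scatter), so this position responds to the aryl swap by more than the scatter. Compound 3 gives > 100000 nM, which is a limit of the assay and not a number. The full size of the step stays unread: the limit of > 100000 nM in this assay, at which 1 of the 3 values shown sits.

The compounds shown do not separate the chlorine from the methyl of 3-chloro-4-methylphenyl. On these data alone, how an aryl group carrying an amine or a carboxylic acid at this position would read in this assay also stays open.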